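Nitro to amino exchange and tolerated concentration

The source may hold more compounds than are shown below. What is called first, only, known or untested is meant among the compounds shown, and "the series" means these compounds.

Measured compounds:
- compound 1 `O=[N+]([O-])c1ccc(-c2nc3cc(C(F)(F)F)ccc3n2C2CCCCC2)cc1`: in an ADME assay on MDBK cells (Bos taurus) for cytotoxicity, read by MTT assay, with a stated time of 96 h (a higher number here means that more compound is tolerated, a lower number that less compound is tolerated), compound 1 gives 68000 nM
- compound 2 `Nc1ccc(-c2nc3cc(C(F)(F)F)ccc3n2C2CCCCC2)cc1`: in this assay compound 2 gives only a limit of the assay, > 100000 nM
- compound 3 `COc1ccc(-c2nc3cc(C(F)(F)F)ccc3[nH]2)c([N+](=O)[O-])c1`: in this assay compound 3 gives 55000 nM

Compound 1 and compound 2 differ by amino in place of nitro on an aromatic carbon. The step is an at least 1.4-fold higher number from compound 1 to compound 2 (0.16 log units; that floor lies within the scatter); its size is open because of the limit of > 100000 nM in this assay, at which 1 of the 3 values shown sits.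

Compound 3 carries a different core; the difference between the core of compound 1 and the core of compound 3 is not broken down here. The values of compound 1 and compound 3 sit within the usual scatter of each other.

Compound 4 `COc1ccc(-c2nc3cc(C(F)(F)F)ccc3[nH]2)c(N)c1` is not yet measured. It differs from compound 3 by amino in place of nitro on an aromatic carbon. This is the same kind of change as from compound 1 to compound 2, but the place differs: there the amino stands para to a large group, here ortho to a large group and meta to a methoxy group.

For compound 4 in this assay the step of a 1.7-fold higher number from compound 3 to compound 4 (0.24 log units; within the scatter) is expected, resting on the measured step of an at least 1.4-fold higher number from compound 1 to compound 2 (0.16 log units; that floor lies within the scatter) and on the value of compound 3, 55000 nM. Compound 4 is estimated at 95000 nM, between 45000 nM and 200000 nM.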

Compound 4, half-maximal cytotoxic concentration: 4000 nM
Estimate against measurement, compound 4: 24-fold (1.38 log units) above; measured number outside the range, below it.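

In this assay, amino in place of nitro on an aromatic carbon gives a 14-fold lower number from compound 3 to compound 4 (1.14 log units; beyond the scatter), so the change does not carry over from one core to the other with the same outcome: the same change on two cores in this assay, an at least 1.4-fold higher number (0.16 log units; that floor lies within the scatter) from compound 1 to compound 2 and a 14-fold lower number (1.14 log units; beyond the scatter) from compound 3 to compound 4, at least 20-fold (1.30 log units) apart, beyond the scatter of two such steps. The earlier step has only a floor and no full size: the limit of > 100000 nM in this assay, at which 1 of the 4 values shown sits. These two pairs do not separate the effect of the core from that of the place of the amino, which in compound 4 stands ortho to a large group and meta to a methoxy group, and they give no rule for any other core in the series.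

From the compounds shown here alone, it remains open whether the lower number of compound 4 depends on the methoxy group, on the place of the amino or on the core as a whole. Also open, going by these compounds, is where a nitrile or an acetylated amine in that same place would fall in this assay, and whether the amino gives the same result on this core without the methoxy group.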